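A Pyridine in Place of Phenyl on a Thiazole Amide

The source may report more compounds than this note shows. Statements on the series, on what has been measured and on what is new or still open speak of the compounds shown alone.

The account follows one change within a small set of cyclohexylpropanamides sharing a common core. Compound 1 `O=C(CCC1CCCCC1)Nc1ncc(Cc2ccccc2)s1` is the reference point. In an ADME assay on P388D1 cells (Mus musculus) for cytotoxicity, read by fluorescence and resazurin assay, with a stated time of 72 h (a higher number here means a weaker inhibitor, a lower number a stronger inhibitor), compound 1 gives > 40000 nM, which is a limit of the assay and not a measured number. Compound 2 `O=C(CCC1CCCCC1)Nc1ncc(Cc2ccnc3ccccc23)s1` belongs to the same set; in this assay compound 2 is recorded as "not determined" (no result reported), so no result exists for it. Within the data shown here, compound 1 therefore stands at the limit of > 40000 nM in this assay, at which 1 of the 2 values shown sits, and no measured step between any two compounds of the set is available.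

Compound 3 `O=C(CCC1CCCCC1)Nc1ncc(Cc2ccccn2)s1` awaits measurement. Its difference from compound 1 is pyridin-2-yl in place of phenyl on a saturated chain carbon bound to an aromatic carbon. Among the measured compounds shown here, with no measured step to lean on, the expectation is that the change produces no shift beyond the usual scatter, and that compound 3 remains at or near the same limit as compound 1, whose reading of > 40000 nM is the only anchor. The estimate for compound 3 in this assay is 50000 nM, with a range from 15000 nM to 160000 nM. The step this estimate implies is expected to be a step that the limit leaves unreadable from compound 1 to compound 3.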

Compound 3, half-maximal inhibitory concentration: > 40000 nM
Compound 3 gave a limit, no number; the forecaster's own chance of this, stated with the estimate: 70%; the middle value does not contradict the limit.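

In this assay no step can be read between compound 1 and compound 3, since each gives only a limit of the assay and not a number: the limit of > 40000 nM in this assay, at which 2 of the 3 values shown sit.

The compounds shown leave open whether pyridin-2-yl in place of phenyl on a saturated chain carbon bound to an aromatic carbon changes the half-maximal inhibitory concentration in this assay at all.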